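The source may report more compounds than this note shows. Statements on the series, on what has been measured and on what is new or still open speak of the compounds shown alone.

The three compounds measured so far:

Compound 1, `CCC1(C)CCOC1=O`: 259 mg/kg
Compound 2, `CC(C)C1(C)CCOC1=O`: 198 mg/kg
Compound 3, `CC(C)C1CCSC1=O`: 145 mg/kg

All three were tested in a functional assay on the whole organism for inhibition, with Mus musculus as the target; on this read-out higher numbers stand for an effect only at larger amounts of compound and lower numbers for an effect already at smaller amounts. Compound 1 and compound 2 share a core and differ in one place: methyl in place of hydrogen on a saturated chain carbon bound to a saturated chain carbon and a saturated ring carbon. That change gave a 1.3-fold lower number from compound 1 to compound 2 (0.12 log units; within the scatter), so the two numbers cannot be told apart with confidence. Compound 3 has a different core; the difference between the two cores is not broken down here. Its number sits close to those of compound 1 and compound 2, with all gaps within the scatter, so no order among the three can be claimed.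

Compound 4, `CC(C)(C)C1CCSC1=O`, has not yet been measured. It stands to compound 3 as compound 2 stands to compound 1: methyl in place of hydrogen on a saturated chain carbon bound to two saturated chain carbons and a saturated ring carbon. The place is not identical, since in compound 1 the carbon that takes the methyl is bound to a saturated chain carbon and a saturated ring carbon, while in compound 3 it is bound to two saturated chain carbons and a saturated ring carbon, so this is the same kind of change rather than the same change. For the measured compounds named here, the only guide is the earlier step, which stayed within the scatter. On that basis the step from compound 3 to compound 4 in this assay is expected to be small, about a 1.2-fold lower number from compound 3 to compound 4 (0.08 log units; within the scatter). Compound 4 is therefore estimated to give 120 mg/kg, most likely between 65 mg/kg and 240 mg/kg.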

Compound 4, dose for half-maximal effect: 244 mg/kg
Beside the measured number, compound 4's estimate is 2.0-fold (0.31 log units) below it, and the stated range ends below it.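

In this assay, putting the methyl in place of hydrogen gave a 1.7-fold higher number from compound 3 to compound 4 (0.23 log units; within the scatter), so on this core, as on the earlier one, the added methyl produced no change that can be told apart from the ordinary spread of repeated measurements. The numbers moved in opposite directions on the two cores, but that difference is no firm sign that the core alters what the methyl does: the same change on two cores in this assay, a 1.3-fold lower number (0.12 log units; within the scatter) from compound 1 to compound 2 and a 1.7-fold higher number (0.23 log units; within the scatter) from compound 3 to compound 4, 2.2-fold (0.34 log units) apart, within the scatter of two such steps

For the compounds shown here, this does not show that the change carries over unchanged from one core to another, only that two small steps, on carbons bound to somewhat different neighbours, give no measurable evidence against it, and any real effect of the methyl smaller than the scatter would stay hidden in these numbers.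

Going by these compounds, all the groups compared at this place are small saturated carbon groups, so it stays open whether a longer chain, a phenyl ring or an amine there would move the number beyond the scatter. No pair shown differs in the core alone, so what the core contributes by itself also remains unknown.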